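Pyrimidine in place of thiazole on the shared core

The compounds below may be only part of what the source reports. "The series", "measured", "known", "first", "only" and "open" are said of these compounds alone.

Measured so far:
Compound 1, `CCn1nc(-c2cccnc2)c2ccccc2c1=O`, in an assay on isolated protein (Oryctolagus cuniculus) with Thromboxane-A synthase (Homo sapiens) as the target, tested at 1 uM; a lower number here means less inhibition, a higher number more inhibition at the concentration tested (going by the name of the read-out): 87%
Compound 2, `CCn1nc(-c2nccs2)c2ccccc2c1=O`, in the same assay: 4%

For the measured compounds named here, compound 2 stands at the bottom of the two numbers; its nearest neighbour is compound 1, and the single measured step, a number 83 percentage points lower from compound 1 to compound 2 (beyond the scatter), lies far beyond the usual scatter. That step, pyridin-3-yl to 1,3-thiazol-2-yl, is the only one that bears on the change now considered.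

Compound 3, `CCn1nc(-c2cncnc2)c2ccccc2c1=O`, differs from compound 2 in one place: pyrimidin-5-yl in place of 1,3-thiazol-2-yl on an aromatic carbon. The entering pyrimidin-5-yl is, like the pyridin-3-yl of compound 1, a six-membered aromatic ring, whereas the leaving group is the five-membered one that went with the low number of compound 2. Going by the values given here, because a number 83 percentage points lower from compound 1 to compound 2 (beyond the scatter) was large, a move back toward the value of compound 1 is expected, though with wide uncertainty since no measured pair has a pyrimidin-5-yl.

For compound 3 an estimate of 55% is made, with a range from 20% to 85%. The step this estimate implies, a number 51 percentage points higher from compound 2 to compound 3 (beyond the scatter), is expected to be upward and beyond the scatter.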

Compound 3, a percentage reported as inhibition, at one concentration (the size of the read-out at that concentration, not a potency): 26%
Estimate against measurement, compound 3: 29 percentage points above, and the stated range covers the measured number.
By their numbers in this assay, from the lowest: compound 2; then compound 3; then compound 1.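

In this assay, a six-membered aromatic ring at this position does not by itself bring back the high number: pyrimidin-5-yl in place of 1,3-thiazol-2-yl gives only a number 22 percentage points higher from compound 2 to compound 3 (beyond the scatter), while pyrimidin-5-yl in place of pyridin-3-yl gives a number 61 percentage points lower from compound 1 to compound 3 (beyond the scatter). Both six-membered rings thus stand above the five-membered 1,3-thiazol-2-yl, yet they also lie far apart from each other, so the change of ring size does not account for the whole spread, and the make-up of the six-membered ring matters to the number in this series of three. Nothing at hand accounts for these differences.

Going by these compounds, it remains open where a plain phenyl ring, a pyridin-4-yl or a pyridin-2-yl would fall at this position, and so whether the placing of the ring nitrogen counts for as much as the change from pyridin-3-yl to pyrimidin-5-yl. Also open, on these data alone, is whether an amine or a carboxylic acid on the pyridin-3-yl ring, or a longer chain in place of the ethyl group, would keep the number of compound 1.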